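A few compounds are considered here, and "the series" means these few. Any claim that something is new, unique, unknown or untested is made for them only; others in the source may bear on it.

Compound 1 `CN1CC2(CC(S(=O)(=O)c3c(Cl)ccc(NC(=O)Nc4cccc(F)c4Cl)c3O)C2)C1` and compound 2 `CN1CC[C@H](S(=O)(=O)c2c(Cl)ccc(NC(=O)Nc3cccc(F)c3Cl)c2O)C1` share a core and differ only in the ring attached to the sulfonyl sulfur. In an ADME assay on the whole organism (blood, Mus musculus, strain C57BL/6) for pharmacokinetics, read by HPLC, with a stated time of 4 h, at a dose of 2 mg/kg by the intraperitoneal route (on this read-out lower numbers stand for lower exposure and higher numbers for higher exposure at the dose given), compound 1 gives 1050 ng.h/mL, while compound 2 gives 432 ng.h/mL, the lower of the two numbers; the step of a 2.4-fold lower number from compound 1 to compound 2 (0.39 log units; beyond the scatter) is modest. Compound 3 `O=C(Nc1ccc(Cl)c(C(=O)N2CCCC2)c1O)Nc1cccc(F)c1Cl` is the new compound: (pyrrolidin-1-yl)carbonyl in place of (1-methylpyrrolidin-3-yl)sulfonyl on an aromatic carbon. Among the measured compounds shown here, no measured step bears on this kind of change, so the expectation rests on compound 2 alone and is uncertain. The expected step of a 1.2-fold higher number from compound 2 to compound 3 (0.06 log units; within the scatter) is small, and compound 3 is estimated at 500 ng.h/mL, within 150 ng.h/mL to 1700 ng.h/mL.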

Compound 3, area under the concentration-time curve: "below limit of detection" (no number reported)
The entry for compound 3 holds no number; the estimate stays without a comparison.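

Among the compounds shown here, compound 3 is reported only as below the limit of detection, a limit with no number, so no step from compound 2 to compound 3 can be read. No evidence on a cause is available. As far as these compounds go, how much exposure compound 3 gives stays open.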